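This account rests on a few compounds, and the source may have more. Where it says the series, first, only, none or still open, it means among the compounds named here.

Working notes on the acylguanidine series in a functional assay for inhibition of sodium/hydrogen exchanger (Oryctolagus cuniculus); on this read-out lower numbers stand for stronger inhibition and higher numbers for weaker inhibition.

Compound 2, `CCc1cc(C)c(C(=O)N=C(N)N)cc1S(C)(=O)=O`, gives 4.8 nM. Compound 1, `Cc1cc(Cl)c(S(C)(=O)=O)cc1C(=O)N=C(N)N`, gives 25 nM. The change from compound 2 to compound 1 is chloro in place of ethyl on an aromatic carbon, and it gave a 5.2-fold higher number from compound 2 to compound 1 (0.72 log units; beyond the scatter). Compound 3, `CCc1cc(OC)c(S(C)(=O)=O)cc1C(=O)N=C(N)N`, gives 30 nM; how the core of compound 3 differs from that of compound 2 is not broken down here, and their values show compound 3 with the higher number of the two. Compound 4, `COc1cc(Cl)c(C(=O)N=C(N)N)cc1S(C)(=O)=O`, is not yet measured; it differs from compound 3 by chloro in place of ethyl on an aromatic carbon. This is the same kind of change as from compound 2 to compound 1, not the same: in compound 1 the chloro sits ortho to a methylsulfonyl group, meta to a methyl group and para to a group of 6 heavy atoms, whereas in compound 4 it sits ortho to a group of 6 heavy atoms, meta to a methoxy group and para to a methylsulfonyl group. For the measured compounds named here, with only one earlier instance of the change, and that at a different place, the expectation for compound 4 rests on compound 1 alone: a step of about a 3.3-fold higher number from compound 3 to compound 4 (0.52 log units; beyond the scatter) is expected, because a 5.2-fold higher number from compound 2 to compound 1 (0.72 log units; beyond the scatter) points to weaker inhibition after this swap. Compound 4 is accordingly estimated at 100 nM, with a range from 35 nM to 300 nM.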

Compound 4, half-maximal inhibitory concentration: 40 nM
Compound 4: middle estimate off by 2.5-fold (0.40 log units), on the high side, and the stated range covers the measured number.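

In this assay, chloro in place of ethyl on an aromatic carbon gave a 1.3-fold higher number from compound 3 to compound 4 (0.12 log units; within the scatter), so the size of this step did not carry over from one core to the other: the same change on two cores in this assay, a 5.2-fold higher number (0.72 log units; beyond the scatter) from compound 2 to compound 1 and a 1.3-fold higher number (0.12 log units; within the scatter) from compound 3 to compound 4, 3.9-fold (0.59 log units) apart, beyond the scatter of two such steps

The swap therefore cannot be treated as a fixed increment in this series, since the earlier step was no guide to the size of the new one. What this does not show is why the two steps differ: the cores differ, and so do the groups around the chloro, which in compound 4 sits ortho to a group of 6 heavy atoms, meta to a methoxy group and para to a methylsulfonyl group, and two pairs cannot separate these factors.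

The compounds shown leave open how a bromo group, an amine or a longer chain would read at this place on either core. They also leave open what step a third core would give for the same swap, and which of the two steps it would more nearly match.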